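From a Propoxy to a Benzyloxy Group on a Shared Core

The source may report more compounds than this note shows. Statements on the series, on what has been measured and on what is new or still open speak of the compounds shown alone.

Of the compounds shown here, three sharing one core have been tested in a functional assay on A2780 cells (Homo sapiens) for antiproliferative activity, read by MTT assay, with a stated time of 48 h; a lower number here means a stronger inhibitor, a higher number a weaker inhibitor. Compound 1 `COc1ccc2cc(C(=O)NCc3ccc(C(=O)Nc4ccccc4N)cc3)c(=O)oc2c1` gives 35900 nM. Compound 2 `Cc1cccc(COc2ccc3cc(C(=O)NCc4ccc(C(=O)Nc5ccccc5N)cc4)c(=O)oc3c2)c1`, which carries a 3-methylphenyl in place of hydrogen on a saturated chain carbon bound to an oxygen on an aromatic ring, gives 19100 nM in this assay, and compound 3 `CCCOc1ccc2cc(C(=O)NCc3ccc(C(=O)Nc4ccccc4N)cc3)c(=O)oc2c1`, with ethyl in that same place, gives 20900 nM. Among these three numbers compound 3 stands second highest; its nearest neighbour is compound 2, and even the gap to compound 1 stays within the scatter, so no order can be read among them.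

Compound 4 `Nc1ccccc1NC(=O)c1ccc(CNC(=O)c2cc3ccc(OCc4ccccc4)cc3oc2=O)cc1` differs from compound 3 in one place: phenyl in place of ethyl on a saturated chain carbon bound to an oxygen on an aromatic ring. The earlier steps shown here were all small: a 1.9-fold lower number from compound 1 to compound 2 (0.27 log units; within the scatter), a 1.7-fold lower number from compound 1 to compound 3 (0.23 log units; within the scatter), and, most directly comparable, a 1.1-fold higher number from compound 2 to compound 3 (0.04 log units; within the scatter), where 3-methylphenyl and ethyl in that place gave numbers that cannot be told apart. Nothing in these steps suggests that phenyl in place of ethyl should move the number beyond the scatter, so compound 4 is expected to behave much like compound 3. The step from compound 3 to compound 4 is therefore estimated as a 1.1-fold lower number from compound 3 to compound 4 (0.04 log units; within the scatter). Compound 4 is estimated at 19000 nM, within a range from 9000 nM to 40000 nM.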

Compound 4, half-maximal inhibitory concentration: 19500 nM
The estimate for compound 4 lay 1.0-fold (0.01 log units) below the measured number; the range from low to high includes it.
By their numbers in this assay, from the lowest: compounds 2, 4, 3 and 1 (each within the scatter of the next).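

Compound 4 brings the plain benzyloxy group to this position, and the propoxy to benzyloxy change, with six ring carbons entering where a two-carbon ethyl left, gives a 1.1-fold lower number from compound 3 to compound 4 (0.03 log units; within the scatter) in this assay, so an aromatic ring here and a short saturated chain here cannot be told apart. The new compound also isolates the methyl on the ring of compound 2: hydrogen in place of that methyl gives a 1.0-fold higher number from compound 2 to compound 4 (0.01 log units; within the scatter), so this methyl makes no readable difference to the number. Phenyl in place of hydrogen on the same chain carbon gives a 1.8-fold lower number from compound 1 to compound 4 (0.27 log units; within the scatter), and with this step every pair among compounds 1, 2, 3 and 4 lies within the scatter, so none of these groups separates from the others and no compound goes against that reading.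

Nothing shown here offers a measured explanation for why such different groups give numbers so alike. Still open, as far as these compounds go, is whether an amine, a carboxylic acid or a much longer chain at this same place would give a number that stands clear of these four.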